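Branching the Unsaturated Amide Chain on a Nitrile Analogue

The source may report more compounds than this note shows. Statements on the series, on what has been measured and on what is new or still open speak of the compounds shown alone.

Of the compounds shown here, three sharing one core have been measured in a functional assay on A-431 cells (Homo sapiens) for inhibition, read by MTT assay, with a stated time of 72 h; a higher number here means a weaker inhibitor, a lower number a stronger inhibitor. Compound 1 is `CC/C=C/C(=O)Nc1cccc(Oc2nc(Nc3cccc(OC)c3)nc3ccsc23)c1` and in this assay compound 1 gives 29200 nM. Compound 2 is `CCC/C=C/C(=O)Nc1cccc(Oc2nc(Nc3cccc(OC)c3)nc3ccsc23)c1`, and in this assay compound 2 gives 8090 nM. Compound 3 is `CC/C=C/C(=O)Nc1cccc(Oc2nc(Nc3cccc(C#N)c3)nc3ccsc23)c1`; in this assay compound 3 gives 36200 nM.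

Compound 2 differs from compound 1 only by methyl in place of hydrogen on a saturated chain carbon, two bonds along the chain from a double-bonded chain carbon, and that change made a 3.6-fold lower number from compound 1 to compound 2 (0.56 log units; beyond the scatter). Compound 3 differs from compound 1 by cyano in place of methoxy on an aromatic carbon, which gave a 1.2-fold higher number from compound 1 to compound 3 (0.09 log units; within the scatter), so the methoxy and cyano variants of the chain of compound 1 cannot be told apart here.

Compound 4, not yet measured, is `CC(C)/C=C/C(=O)Nc1cccc(Oc2nc(Nc3cccc(C#N)c3)nc3ccsc23)c1`. It differs from compound 3 by methyl in place of hydrogen on a saturated chain carbon bound to a double-bonded chain carbon and a saturated chain carbon. Among the measured compounds shown here, this is the same kind of change as the one from compound 1 to compound 2, not the same change: there the methyl entered on a saturated chain carbon, two bonds along the chain from a double-bonded chain carbon, whereas here it enters on a saturated chain carbon bound to a double-bonded chain carbon and a saturated chain carbon. For the measured compounds named here, only one earlier instance of adding a methyl to this chain exists, compound 1 to compound 2, so the expectation rests on a single step at a different place.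

For compound 4 a step of a 2.3-fold lower number from compound 3 to compound 4 (0.35 log units; beyond the scatter) is expected, somewhat smaller than the earlier methyl step, because a 3.6-fold lower number from compound 1 to compound 2 (0.56 log units; beyond the scatter) was measured with the methyl entering at a different place on the chain. The estimated value for compound 4 in this assay is 16000 nM, expected to lie between 5000 nM and 45000 nM.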

Compound 4, half-maximal inhibitory concentration: 24100 nM
Compound 4: middle estimate off by 1.5-fold (0.18 log units), on the low side; the measured number falls inside the stated range.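

In this assay, the methyl step on the nitrile compound, a 1.5-fold lower number from compound 3 to compound 4 (0.18 log units; within the scatter), is too small to separate compound 4 from compound 3. Set beside the earlier methyl step, it does not differ by more than two such steps can differ through scatter alone: the same change on two cores in this assay, a 3.6-fold lower number (0.56 log units; beyond the scatter) from compound 1 to compound 2 and a 1.5-fold lower number (0.18 log units; within the scatter) from compound 3 to compound 4, 2.4-fold (0.38 log units) apart, within the scatter of two such steps. Among the compounds shown here, this means the data give no sign that the methoxy and nitrile compounds respond differently to adding a methyl, but they do not show that the step carries over unchanged, since there is only one pair on each side, only the earlier step lies beyond the scatter, and the methyl enters at a different place on the chain in each pair, so the place and the aromatic group vary together.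

On these data alone, what remains open is how the 3-methylbut-1-en-1-yl chain would behave with the methoxy group and how the chain of compound 2 would behave with the nitrile, two pairings that would let the place of the methyl be judged apart from the aromatic group. Also open, as far as these compounds go, is whether a longer chain, or an amine on the chain, would move the number further than any methyl step seen here.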